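Rearranging the Same Atoms on a Carbonyl Carbon

The source may report more compounds than this note shows. Statements on the series, on what has been measured and on what is new or still open speak of the compounds shown alone.

Compound 1 `O=C(NCc1ccc(S(=O)(=O)c2ccccc2)cc1)c1nc2ccncc2s1`: 26%
Compound 2 `O=C(NCc1ccc(S(=O)(=O)c2ccccc2)cc1)c1ccc2nccn2c1`: 18%

In an ADME assay on microsomes from liver (Mus musculus) for metabolic stability, read by LC-MS, with a stated time of 30 min, tested at 1 uM (on this read-out higher numbers stand for a more stable compound and lower numbers for a less stable compound), compound 2 gives 18%. Going by the values given here, only one other number stands beside it, and compound 1 with 26% lies within the scatter of it, so the two cannot be told apart.

Compound 3 `O=C(NCc1ccc(S(=O)(=O)c2ccccc2)cc1)c1c[nH]c2ccncc12` has not yet been measured. It has the same atoms as compound 2, joined differently: a group of 9 heavy atoms (7 carbon, 2 nitrogen; one five-membered aromatic ring with 1 hetero atom, one six-membered aromatic ring with 1 hetero atom) in place of a group of 9 heavy atoms (7 carbon, 2 nitrogen; one five-membered aromatic ring with 2 hetero atoms, one six-membered aromatic ring with 1 hetero atom), on a carbonyl carbon. The change again falls on a carbonyl carbon whose other neighbours are: amide-type nitrogen.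

Just one measured step bears on this, an exchange of groups at that same place: a number 8 percentage points lower from compound 1 to compound 2 (within the scatter). That step stayed within the scatter. Among the compounds with values here, no measured compound carries the entering group, so this single step is a thin guide, and the range has to stay wide. Nothing in the data points to a direction, and no shift beyond the scatter is expected. The step expected is a number 2 percentage points higher from compound 2 to compound 3 (within the scatter). For compound 3 the estimated value in this assay is 20%, with an expected range from 8% to 36%.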

Compound 3, percent of the compound remaining: 45%
For compound 3 the middle estimate is 25 percentage points below the measured one; the whole stated range lies below it.
By their numbers in this assay, from the lowest: compounds 2 and 1 (each within the scatter of the next); then compound 3.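

In this assay, going by these compounds alone, the group on the carbonyl carbon proves able to move the read-out beyond the scatter, with a number 27 percentage points higher from compound 2 to compound 3 (beyond the scatter) and a number 19 percentage points higher from compound 1 to compound 3 (beyond the scatter), whereas the only earlier step at this place stayed within it. Since compound 2 and compound 3 hold the same atoms, joining them differently is enough to produce a step of this size, with the entering group having 1 hydrogen-bond donor and 1 hydrogen-bond acceptor where the leaving group has 0 hydrogen-bond donors and 2 hydrogen-bond acceptors. No measurement at hand explains the rise, and the link to those counts remains only an observation from this single pair.

The compounds shown do not separate the hydrogen-bond donor of compound 3 from the other differences in how its group is joined, so it remains open which of them goes with the higher number. As far as these compounds go, it also remains open whether the number in this assay would hold if a methyl group or a chlorine atom were added to the entering group, or whether the same exchange would give a similar step on a different core.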